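This account rests on a few compounds, and the source may have more. Where it says the series, first, only, none or still open, it means among the compounds named here.

Measured compounds:
compound 1 `Cc1cc(C(=O)O)cc(C)c1NC(=O)c1cc(-c2cccc(CO)c2)ccc1F`: 47.8 nM
compound 2 `Cc1ccc(C(=O)O)c(C)c1NC(=O)c1nc(-c2cccc(CO)c2)ccc1C(F)(F)F`: 59 nM
compound 3 `Cc1ccc(C(=O)O)c(C)c1NC(=O)c1cc(-c2cccc(CO)c2)ccc1F`: 72.4 nM

In an assay on blood for antagonist activity at prostaglandin E2 receptor EP4 subtype (Homo sapiens), read by immunoassay, with stated times of 30 min and 24 h (a lower number here means a stronger inhibitor, a higher number a weaker inhibitor), compound 1 has the lowest of the three numbers, yet its gaps to compound 2 and to compound 3 both lie within the scatter, so the three values cannot be set in order. The untested compound 4 `Cc1ccc(-c2cccc(CO)c2)cc1C(=O)Nc1c(C)cc(C(=O)O)cc1C` is reached from compound 1 by a single change: methyl in place of fluoro on an aromatic carbon. Going by the values given here, no measured pair in this set shows this same change, so there is nothing to read a direction from; a swap of one heavy atom for another of the same size, with no change in donors, acceptors or charge, is expected to move the number by no more than the scatter, in either direction. Compound 4 is therefore estimated at 55 nM, within 20 nM to 150 nM. The expected step is a 1.2-fold higher number from compound 1 to compound 4 (0.06 log units; within the scatter), not beyond the scatter.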

Compound 4, half-maximal inhibitory concentration in the prostaglandin E2 receptor EP4 subtype assay: 18.7 nM
Compound 4: middle estimate off by 2.9-fold (0.47 log units), on the high side, outside the stated range (below it).
By their numbers in the prostaglandin E2 receptor EP4 subtype assay, from the lowest: compound 4; then compounds 1, 2 and 3 (each within the scatter of the next).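

Going by these compounds alone, in the prostaglandin E2 receptor EP4 subtype assay, methyl in place of fluoro on this aromatic carbon, ortho to a large group, gives a 2.6-fold lower number from compound 1 to compound 4 (0.41 log units; beyond the scatter); the earlier compounds, which differ in more than one place, could not show that this single-atom swap matters here. In a physicochemical assay for solubility, read by HPLC, with a stated time of 20 h, at pH 6 (on this read-out higher numbers stand for higher solubility and lower numbers for lower solubility), the same change carries a much larger cost: the measured solubility of compound 1, 774 ug/mL, and of compound 4, 31 ug/mL, a 25-fold lower number (1.40 log units; beyond the scatter)
In the physicochemical assay compound 1 gives 774 ug/mL and compound 4 gives 31 ug/mL as its measured value.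

The compounds shown leave open whether chloro, methoxy or an amine on this carbon would keep the number of compound 4 in the prostaglandin E2 receptor EP4 subtype assay without the loss in the physicochemical assay. As far as these compounds go, whether the same swap acts alike in compound 3 also remains open.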